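Opening the step from a hexyl chain to a cyanobenzyl group

The source may report more compounds than this note shows. Statements on the series, on what has been measured and on what is new or still open speak of the compounds shown alone.

Compound 1 `COc1ccc2nccc(C3CN(C4CCN(Cc5cc6ccccc6o5)CC4)C(=O)O3)c2c1`: 1260 nM
Compound 2 `COc1ccc2nccc(C3CN(C4CCN(C)CC4)C(=O)O3)c2c1`: < 50200 nM
Compound 3 `CCCCCCN1CCC(N2CC(c3ccnc4ccc(OC)cc34)OC2=O)CC1`: 501 nM

In an in vitro functional assay on RBL cells for antagonist activity at C-C chemokine receptor type 8 (Homo sapiens), read by FLIPR and calcium flux (a higher number here means a weaker inhibitor, a lower number a stronger inhibitor), compound 3 gives the lowest of the two numbers shown; compound 1 sits higher, as a 2.5-fold lower number from compound 1 to compound 3 (0.40 log units; beyond the scatter) records. The value of compound 2 is a limit of this assay, not a number (the limit of < 50200 nM in this assay, at which 1 of the 3 values shown sits), so the steps from it cannot be read in size.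

Compound 4 `COc1ccc2nccc(C3CN(C4CCN(Cc5ccc(C#N)cc5)CC4)C(=O)O3)c2c1` has not been measured. The change from compound 3 is 4-cyanophenyl in place of pentyl on a saturated chain carbon bound to an amine nitrogen in a ring. Within the data shown here, the only readable step on this position, a 2.5-fold lower number from compound 1 to compound 3 (0.40 log units; beyond the scatter), shows that a benzofuranylmethyl group gives a higher number than hexyl. A cyanobenzyl group is likewise an aromatic ring on that carbon, so compound 4 is expected to sit above compound 3 by roughly a 2.2-fold higher number from compound 3 to compound 4 (0.34 log units; beyond the scatter), with an estimated value of 1100 nM in a range from 350 nM to 3500 nM.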

Compound 4, half-maximal inhibitory concentration: 12600 nM
Compound 4: the middle estimate sits 11-fold (1.06 log units) below what was measured, and the stated range ends below it.
By their numbers in this assay, from the lowest: compound 3; then compound 1; then compound 4.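

In this assay, replacing the chain with an aromatic group costs far more here than the benzofuranylmethyl case suggested, with a 25-fold higher number from compound 3 to compound 4 (1.40 log units; beyond the scatter). An aromatic ring on this carbon therefore does not fix the number by itself, since the two aromatic groups also differ, with a 10-fold higher number from compound 1 to compound 4 (1.00 log units; beyond the scatter). Compound 2 carries a limit rather than a number, so its steps cannot be read: the limit of < 50200 nM in this assay, at which 1 of the 4 values shown sits.

The compounds shown leave open whether a plain benzyl group, without the nitrile, would sit nearer compound 1 or compound 4. They also leave open whether a chain longer than hexyl would give a lower number than compound 3.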